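The compounds below may be only part of what the source reports. "The series", "measured", "known", "first", "only" and "open" are said of these compounds alone.

Compound 1 `CCCCOC(=O)CC1C(C(=O)OCCCC)=C(N)Oc2ccc(-c3cc(OC)cc(OC)c3)cc21`: 32000 nM
Compound 2 `CCOC(=O)CC1C(C(=O)OCC)=C(N)Oc2ccc(-c3cccc(F)c3)cc21`: 76400 nM

In a functional assay on HL-60 cells (Homo sapiens) for cytotoxicity, read by CellTiter-Blue, with a stated time of 48 h (on this read-out lower numbers stand for stronger inhibition and higher numbers for weaker inhibition), compound 2 gives 76400 nM, the higher of the two numbers and so the weaker inhibition, and the gap to compound 1 lies beyond the scatter. Compound 3 `CCOC(=O)CC1C(C(=O)OCC)=C(N)Oc2ccc(-c3cccs3)cc21` has thiophen-2-yl in place of 3-fluorophenyl on an aromatic carbon. For the measured compounds named here, no measured pair shows this change, so the starting point is compound 2 at 76400 nM. The estimated step of a 1.3-fold lower number from compound 2 to compound 3 (0.10 log units; within the scatter) is small, expected to stay within the scatter. For compound 3 the expected value is 60000 nM, with an estimated range from 25000 nM to 130000 nM.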

Compound 3, half-maximal inhibitory concentration: > 80000 nM
Compound 3 gave a limit, no number; the forecaster's own chance of this, stated with the estimate: 15%; at least 1.3-fold (0.12 log units) between middle value and limit.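

Replacing 3-fluorophenyl with thiophen-2-yl on this aromatic carbon gives an at least 1.0-fold higher number from compound 2 to compound 3 (0.01 log units; that floor lies within the scatter) in this assay, the first step seen at this position. The result gives no sign of stronger inhibition with the five-membered sulfur ring in this place. For compound 3 the assay yields a limit and not a number, leaving the true size of the step unresolved: the limit of > 80000 nM in this assay, at which 1 of the 3 values shown sits.

The compounds shown leave open how an amine or a carboxylic acid on this carbon would read. They also do not separate the contribution of the butyl esters of compound 1 from that of its dimethoxyphenyl group.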